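The compounds below may be only part of what the source reports. "The series", "measured", "known", "first", "only" and "open" are said of these compounds alone.

Among the compounds with values here, in a functional assay (lung) for inhibition, with Cavia porcellus as the target (on this read-out lower numbers stand for stronger inhibition and higher numbers for weaker inhibition), compound 3 (`CC(CCC(=O)O)Cc1cccc(OCc2ccc3ccccc3n2)c1`) gives 500 nM, the highest of the three numbers so far, against 65 nM for compound 2 (`O=C(O)CCC(Cc1ccc(OCc2ccc3ccccc3n2)cc1)c1ccccc1`) and 45 nM for compound 1 (`CC(CCc1cccc(OCc2ccc3ccccc3n2)c1)Cc1nnn[nH]1`). Compound 4 (`CC(CCCC(=O)O)c1cccc(OCc2ccc3ccccc3n2)c1`) has the same atoms, joined differently: 4-carboxy-1-methylbutyl in place of 4-carboxy-2-methylbutyl on an aromatic carbon. On an aromatic carbon, 4-carboxy-1-methylbutyl stands in place of 4-carboxy-2-methylbutyl. Within the data shown here, the one measured step, an 11-fold higher number from compound 1 to compound 3 (1.05 log units; beyond the scatter), is large, but it is a different change and gives no direction here. Among the measured compounds shown here, no measured step moves the methyl along the chain. The step expected in this assay is therefore small and without a supported direction, estimated as a 1.4-fold lower number from compound 3 to compound 4 (0.15 log units; within the scatter). For compound 4 the expected value is 350 nM, within an estimated range of 100 nM to 1200 nM.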

Compound 4, half-maximal inhibitory concentration: 500 nM
Compound 4: middle estimate off by 1.4-fold (0.15 log units), on the low side; the range from low to high includes it.
By their numbers in this assay, from the lowest: compounds 1 and 2 (each within the scatter of the next); then compounds 3 and 4 (each within the scatter of the next).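

In this assay, moving the methyl along the chain, with 4-carboxy-1-methylbutyl in place of 4-carboxy-2-methylbutyl on an aromatic carbon, gives no change at the digits printed from compound 3 to compound 4 (within the scatter) and so leaves the read-out unmoved. The earlier compounds shown here offered only a larger change at this position, an 11-fold higher number from compound 1 to compound 3 (1.05 log units; beyond the scatter) and no shift of the methyl alone. Nothing available explains why the two chains read alike. The compounds shown leave open whether an ethyl in place of the methyl, or an amide in place of the carboxylic acid, would move this number.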